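A few compounds are considered here, and "the series" means these few. Any claim that something is new, unique, unknown or untested is made for them only; others in the source may bear on it.

Measured so far in a functional assay on A549 cells (Homo sapiens) for antiproliferative activity, read by MTT assay, with a stated time of 48 h; a higher number here means a weaker inhibitor, a lower number a stronger inhibitor:

Compound 1 `O=[N+]([O-])c1cc(C(F)(F)F)cc([N+](=O)[O-])c1Oc1ccc(Cl)cc1/C=N\OCc1ccccc1` gives 3410 nM.
Compound 2 `O=[N+]([O-])c1cc(C(F)(F)F)cc([N+](=O)[O-])c1Oc1ccc(Cl)cc1/C=N\OCc1ccccc1F` gives 2570 nM.
Compound 3 `O=[N+]([O-])c1cc(C(F)(F)F)cc([N+](=O)[O-])c1Oc1ccc(Br)cc1/C=N\OCc1ccccc1` gives 2240 nM.

All three compounds share one core; the third member, compound 3, differs from compound 1 in one spot: bromo in place of chloro on an aromatic carbon. That exchange gave a 1.5-fold lower number from compound 1 to compound 3 (0.18 log units; within the scatter). Compound 2 differs from compound 1 in another spot: fluoro in place of hydrogen on an aromatic carbon. That step was a 1.3-fold lower number from compound 1 to compound 2 (0.12 log units; within the scatter). Every gap among the three measured values is within the usual scatter, so none of them can be called stronger or weaker than another.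

Compound 4 `O=[N+]([O-])c1cc(C(F)(F)F)cc([N+](=O)[O-])c1Oc1ccc(Br)cc1/C=N\OCc1ccccc1F` has not yet been measured in this assay. It carries the core of compound 3 and differs from it thus: fluoro in place of hydrogen on an aromatic carbon. This is the same change that turned compound 1 into compound 2, and its place is described in the same words in both cases; only the surrounding core differs, by the exchange already told.

From compound 3 to compound 4 the expected step is a 1.2-fold lower number from compound 3 to compound 4 (0.09 log units; within the scatter), because the same change gave a 1.3-fold lower number from compound 1 to compound 2 (0.12 log units; within the scatter). Compound 4 is therefore estimated at about 1800 nM, expected to fall between 900 nM and 3600 nM.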

Compound 4, half-maximal inhibitory concentration: 1280 nM
Compound 4: the middle estimate sits 1.4-fold (0.15 log units) above what was measured, within the range that was stated.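

In this assay, fluoro in place of hydrogen, which turns benzyl into 2-fluorobenzyl, gave a 1.8-fold lower number from compound 3 to compound 4 (0.24 log units; within the scatter), and this agrees with the earlier step for the same change: the same change on two cores in this assay, a 1.3-fold lower number (0.12 log units; within the scatter) from compound 1 to compound 2 and a 1.8-fold lower number (0.24 log units; within the scatter) from compound 3 to compound 4, 1.3-fold (0.12 log units) apart, within the scatter of two such steps

Bromo in place of chloro gave a 2.0-fold lower number from compound 2 to compound 4 (0.30 log units; within the scatter), and this also agrees with its earlier counterpart: the same change on two cores in this assay, a 1.5-fold lower number (0.18 log units; within the scatter) from compound 1 to compound 3 and a 2.0-fold lower number (0.30 log units; within the scatter) from compound 2 to compound 4, 1.3-fold (0.12 log units) apart, within the scatter of two such steps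

So each change behaved alike on the two cores as far as these numbers can tell, but every one of these steps lies within the scatter, so this does not show that either change truly moves the number, and two cores cannot establish a rule for the whole series.

The compounds shown vary only between hydrogen and fluoro at one spot and between chloro and bromo at another. From the compounds shown here alone, it remains open whether a different group, such as an amine or a methoxy group in place of the fluoro, or a longer chain in place of benzyl, would give a step beyond the scatter, and whether that step would carry from one core to the other.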